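The source may report more compounds than this note shows. Statements on the series, on what has been measured and on what is new or still open speak of the compounds shown alone.

Of the compounds shown here, three have so far been measured in a functional assay on HEK293 cells for antagonist activity at cysteinyl leukotriene receptor 2 (Homo sapiens), read by fluorescence and calcium flux, with stated times of 30 min and 1 h; on this read-out higher numbers stand for weaker inhibition and lower numbers for stronger inhibition. Compound 1 `Cc1c(Cl)cccc1CCCCOc1ccc(C#Cc2cccc3c(CCC(=O)O)c(C)n(CCCCC(=O)O)c23)cc1` gives 60 nM in this assay. Compound 2 `Cc1c(F)cccc1CCCCOc1ccc(/C=C/c2cccc3c(CCCC(=O)O)c(C)n(CC(=O)O)c23)cc1` gives 7.2 nM in this assay. Compound 3 `Cc1c(F)cccc1CCCCOc1ccc(/C=C/c2cccc3c(CCCC(=O)O)cn(CC(=O)O)c23)cc1` gives 14 nM in this assay, the second highest of the three numbers. Its nearest neighbour is compound 2, and the single-point step a 1.9-fold higher number from compound 2 to compound 3 (0.29 log units; within the scatter) rests on hydrogen in place of methyl on an aromatic carbon. Compound 1, whose number lies furthest from that of compound 3, differs from it in several places at once, so the two values show only that their gap lies beyond the scatter.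

Compound 4 `O=C(O)CCCc1cn(CC(=O)O)c2c(/C=C/c3ccc(OCCCCOc4ccccc4)cc3)cccc12` has not yet been measured. It differs from compound 3 in one place: phenoxy in place of 3-fluoro-2-methylphenyl on a saturated chain carbon, four bonds along the chain from an oxygen on an aromatic ring. For the measured compounds named here, no measured step covers this exchange. Going by the values given here, the one single-point step known, a 1.9-fold higher number from compound 2 to compound 3 (0.29 log units; within the scatter), touches only a methyl on an aromatic carbon and stayed within the scatter, so it offers no guide to replacing the whole 3-fluoro-2-methylphenyl with phenoxy. Among the compounds with values here, with no step to lean on, the expectation is a step of a 2.1-fold higher number from compound 3 to compound 4 (0.33 log units; beyond the scatter), with a weaker inhibition held as the somewhat more likely direction and a wide spread allowed. Compound 4 is therefore estimated at 30 nM, within a range from 8 nM to 120 nM.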

Compound 4, half-maximal inhibitory concentration in the cysteinyl leukotriene receptor 2 assay: 6 nM
Estimate against measurement, compound 4: 5.0-fold (0.70 log units) above, outside the stated range (below it).
By their numbers in the cysteinyl leukotriene receptor 2 assay, from the lowest: compounds 4, 2 and 3 (each within the scatter of the next, the first and the last beyond it); then compound 1.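

In the cysteinyl leukotriene receptor 2 assay, phenoxy in place of 3-fluoro-2-methylphenyl gives a 2.3-fold lower number from compound 3 to compound 4 (0.37 log units; beyond the scatter), a modest gain in inhibition. For the compounds shown here, the only earlier single-place step touched a methyl on an aromatic carbon and stayed within the scatter, whereas this one replaces a whole ring group, on a saturated chain carbon, four bonds along the chain from an oxygen on an aromatic ring, and the change in the number goes beyond the scatter, so activity at this receptor responds to this place and does not depend on keeping the methyl and the fluorine. The same exchange also carries a cost in a physicochemical assay for permeability, using PAMPA, with a stated time of 4 h, at pH 6.2, tested at 50 uM (on this read-out higher numbers stand for higher permeability and lower numbers for lower permeability), where compound 3 gives 3.5 10^-6 cm/s and compound 4 gives 1.6 10^-6 cm/s, and the better inhibitor is the less permeable of the pair: the measured apparent permeability of compound 3, 3.5 10^-6 cm/s, and of compound 4, 1.6 10^-6 cm/s, a 2.2-fold lower number (0.34 log units; beyond the scatter).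

The exchange removes a methyl and a fluorine and brings in an oxygen all at once, so these compounds cannot tell which of those changes accounts for either shift, and a plain phenyl on the same chain would help to separate them. Also open, on these data alone, is whether a methoxy or a nitrile on the phenoxy ring could keep the inhibition while recovering the permeability.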